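The source may hold more compounds than are shown below. What is called first, only, known or untested is meant among the compounds shown, and "the series" means these compounds.

Three compounds share one core and differ only in the group on a single aromatic carbon. Compound 1 `CC(C)N(Cc1cccc(OCCCCCC(=O)O)c1)C(=O)c1ccc(-c2cccc(N(C)C)c2)cc1` carries a dimethylamino group there. In an ADME assay on BJ cells (Homo sapiens) for cytotoxicity, read by CellTiter-Glo and resazurin assay, with a stated time of 72 h (a higher number here means that more compound is needed for the effect, a lower number that less compound is needed), compound 1 gives > 26000 nM, which is a limit of the assay and not a number. Compound 2 `CC(=O)Nc1cccc(-c2ccc(C(=O)N(Cc3cccc(OCCCCCC(=O)O)c3)C(C)C)cc2)c1` carries an acetamido group in that place. In this assay compound 2 gives > 26000 nM, again a limit rather than a measured number. Compound 3 `CC(=O)c1cccc(-c2ccc(C(=O)N(Cc3cccc(OCCCCCC(=O)O)c3)C(C)C)cc2)c1` carries an acetyl group. In this assay compound 3 gives > 26000 nM, also a limit. Compound 3 thus stands at the limit of > 26000 nM in this assay, at which 3 of the 3 values shown sit, and no compound shown separates from it. The steps a step that the two limits leave unreadable from compound 1 to compound 2, a step that the two limits leave unreadable from compound 1 to compound 3 and a step that the two limits leave unreadable from compound 2 to compound 3 therefore have no readable size, since each end sits at the same limit.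

Compound 4 `CC(C)COc1cccc(-c2ccc(C(=O)N(Cc3cccc(OCCCCCC(=O)O)c3)C(C)C)cc2)c1` has not yet been measured. Its change from compound 3 is isobutoxy in place of acetyl on an aromatic carbon. All three steps measured so far bear on this position, and none of them moved the value off the limit, so no step beyond the scatter is expected in this assay in either direction. Compound 4 is expected to give about 26000 nM, within 10000 nM to 60000 nM, most likely reported again as a limit. The expected step is a number no higher from compound 3 to compound 4 (the limit leaves the size open).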

Compound 4, half-maximal effective concentration: > 26000 nM
Compound 4: only a limit was reported; the forecaster's own chance of this, stated with the estimate: 85%; the middle value lies on the limit itself.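

In this assay compound 4 gives > 26000 nM and this is a limit of the assay, not a number. Going by these compounds alone, no step from compound 1, compound 2 or compound 3 to compound 4 can be read, since all sit at one limit: the limit of > 26000 nM in this assay, at which 4 of the 4 values shown sit. The compounds shown leave open whether any group in this place brings the value off the limit.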